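Carboxy for Cyano on the Shared Core

A few compounds are considered here, and "the series" means these few. Any claim that something is new, unique, unknown or untested is made for them only; others in the source may bear on it.

Three compounds share one core and differ only on the phenyl group. In a functional assay on the whole organism (strain albino) for inhibition, with Rattus norvegicus as the target, read by paw edema, with a stated time of 1 h, at a dose of 100 mg/kg by the oral route (a higher number here means more inhibition at the dose given (going by the name of the read-out), a lower number less inhibition), compound 1 `N#Cc1c(-c2ccccc2)nc(SCC(=O)Nn2c(COc3ccc(Cl)cc3Cl)nc3ccccc3c2=O)[nH]c1=O` gives 81.8%, the highest of the three numbers. Compound 2 `N#Cc1c(-c2ccc(Cl)cc2)nc(SCC(=O)Nn2c(COc3ccc(Cl)cc3Cl)nc3ccccc3c2=O)[nH]c1=O` gives 63.6%, and compound 3 `N#Cc1c(-c2ccc(O)cc2)nc(SCC(=O)Nn2c(COc3ccc(Cl)cc3Cl)nc3ccccc3c2=O)[nH]c1=O` gives 63.6%. The change from compound 1 to compound 2 brought a number 18.2 percentage points lower from compound 1 to compound 2 (beyond the scatter), from compound 1 to compound 3 a number 18.2 percentage points lower from compound 1 to compound 3 (beyond the scatter), and between the two lower compounds no change at the digits printed from compound 2 to compound 3 (within the scatter).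

Compound 4 `O=C(CSc1nc(-c2ccccc2)c(C(=O)O)c(=O)[nH]1)Nn1c(COc2ccc(Cl)cc2Cl)nc2ccccc2c1=O` differs from compound 1 elsewhere: carboxy in place of cyano on an aromatic carbon. Among the compounds with values here, no measured step touches this position; the two steps seen were each modest and sat on the phenyl group, so they give no direct guide. A step of uncertain direction, probably small, is expected, a number 13.8 percentage points lower from compound 1 to compound 4 (beyond the scatter). Compound 4 is estimated at 68%, in the range 50% to 85%.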

Compound 4, a percentage reported as inhibition, in the whole organism at one dose (the size of the read-out at that dose, not a potency): 69.1%
Beside the measured number, compound 4's estimate is 1.1 percentage points below it; the measured number falls inside the stated range.
By their numbers in this assay, from the lowest: compounds 2, 3 and 4 (each within the scatter of the next); then compound 1.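

Carboxy in place of cyano gives a number 12.7 percentage points lower from compound 1 to compound 4 (beyond the scatter) in this assay, so this position, untouched by the earlier phenyl changes, also affects the read-out. The step is modest, and compound 4 still gives 69.1%, so this change lowers inhibition without abolishing it. Nothing shown here gives a reason for the step. Still open, from the compounds shown here alone, is how an amine or a methyl ester would behave at this position. It is also unknown whether carboxy would give a step of similar size with chloro or hydroxy on the phenyl group.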